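From chloro to bromo: a step among limits

The source may hold more compounds than are shown below. What is called first, only, known or untested is meant among the compounds shown, and "the series" means these compounds.

Compound 1 `CCc1cccc(CNC(=O)c2nc3ccc(F)c(COCc4ccc(C(=O)O)cc4)c3c(=O)[nH]2)c1`: > 20000 nM, a limit
Compound 2 `CCc1cccc(CNC(=O)c2nc3cccc(COCc4ccc(C(=O)O)cc4)c3c(=O)[nH]2)c1`: > 40000 nM, a limit
Compound 3 `CCc1cccc(CNC(=O)c2nc3ccc(Cl)c(COCc4ccc(C(=O)O)cc4)c3c(=O)[nH]2)c1`: > 20000 nM, a limit

All three entries come from an ADME assay on HEK293 cells (Homo sapiens) for cytotoxicity, read by resazurin assay, with a stated time of 72 h (a lower number here means that less compound is tolerated, a higher number that more compound is tolerated), and none of them is a number. Compound 4 `CCc1cccc(CNC(=O)c2nc3ccc(Br)c(COCc4ccc(C(=O)O)cc4)c3c(=O)[nH]2)c1` differs from compound 3 by one change, bromo in place of chloro on an aromatic carbon, ortho to a ((4-carboxybenzyl)oxy)methyl group. The measured steps that bear on it are a step that the two limits leave unreadable from compound 1 to compound 3 and a step that the two limits leave unreadable from compound 2 to compound 3, and neither has a readable size. No shift beyond the scatter is therefore expected, in either direction, and another limit is the likeliest report. The estimated change is a step that the limit leaves unreadable from compound 3 to compound 4. Compound 4 is estimated at 30000 nM, with an expected range from 15000 nM to 60000 nM.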

Compound 4, half-maximal cytotoxic concentration: > 20000 nM
Compound 4 ended at the assay's limit; the forecaster's own chance of this, stated with the estimate: 85%; the middle value lies beyond the limit too.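

All four values in this assay are limits, and the steps linking compound 4 with compound 1, compound 2 and compound 3 cannot be read. The compounds shown leave open at what concentration any of them reaches half-maximal cytotoxicity.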